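A few compounds are considered here, and "the series" means these few. Any claim that something is new, unique, unknown or untested is made for them only; others in the source may bear on it.

Measured compounds:
- compound 1 `Cc1nc(-c2ccccc2)c(C(=O)N2CCN(c3cccc(C)c3C)CC2)o1`: 35 nM
- compound 2 `Cc1nc(-c2ccccc2Cl)c(C(=O)N2CCN(c3cccc(Cl)c3)CC2)o1`: 132 nM
- compound 3 `O=C(c1oc(C(F)(F)F)nc1-c1ccc(F)cc1)N1CCN(c2cccc(Cl)c2)CC1`: "not active" (no number reported)

All three were tested in a functional assay on HL-60 cells (Homo sapiens) for inhibition, read by MTT assay, with a stated time of 72 h; on this read-out lower numbers stand for stronger inhibition and higher numbers for weaker inhibition. Of the two compounds that gave a number, compound 1 stands lowest, and compound 2 sits at a higher number, a gap beyond the usual scatter of repeated measurements. For compound 3 this assay reports "not active" (no number reported) and no number.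

The next compound, compound 4 `CC(=O)Nc1cccc(N2CCN(C(=O)c3oc(C)nc3-c3ccccc3)CC2)c1`, has not yet been measured. It keeps the core of compound 1 and changes one group:

3-acetamidophenyl in place of 2,3-dimethylphenyl on an amine nitrogen in a ring

Going by the values given here, no measured pair shows this kind of change, so there is no step in the data to lean on; the only guide is that compound 1 gives 35 nM and that compound 2, which carries a different group at the same place, gives 132 nM. A change of group on that ring nitrogen can therefore move the number noticeably. With a larger group that brings one hydrogen-bond donor and one hydrogen-bond acceptor, the number is expected to rise, though not far, in this assay. The step from compound 1 to compound 4 is estimated as a 2.9-fold higher number from compound 1 to compound 4 (0.46 log units; beyond the scatter). Compound 4 is expected to give about 100 nM, within a range from 30 nM to 400 nM.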

Compound 4, half-maximal inhibitory concentration: 329 nM
Estimate against measurement, compound 4: 3.3-fold (0.52 log units) below; measured number inside the range.
By their numbers in this assay, from the lowest: compound 1; then compound 2; then compound 4.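

In this assay, going by these compounds alone, placing 3-acetamidophenyl in place of 2,3-dimethylphenyl on the amine nitrogen of the six-membered ring gives a 9.4-fold higher number from compound 1 to compound 4 (0.97 log units; beyond the scatter), a step beyond the scatter and the first one in which only this position changes. The earlier compounds shown here could not show this, since those with numbers differ in more than one place; now the group on that nitrogen is seen to move the number on its own, while compound 4 still gives a measurable 329 nM. Nothing available explains why the number rises with this change.

The step removes the methyl groups and adds the acetamide at the same time, and it brings in 1 hydrogen-bond donor and 1 hydrogen-bond acceptor, so the compounds shown leave open which part of the swap accounts for the rise. An unsubstituted phenyl ring on that nitrogen could separate the loss of the methyl groups from the gain of the acetamide, and an amine or a carboxylic acid in place of the acetamide could show how much depends on the acetamide itself.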